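Notes on a diaryl-amide series against Rho kinase

The compounds below may be only part of what the source reports. "The series", "measured", "known", "first", "only" and "open" are said of these compounds alone.

Measured compounds:
compound 1, `COc1cccc(OCC(=O)Nc2cccc(NC(=O)c3ccc(N(C)C)cc3)c2)c1`: > 10000 nM
compound 2, `Cc1coc2cc(OCC(=O)Nc3cccc(NC(=O)c4ccc(N(C)C)cc4)c3)ccc2c1=O`: > 10000 nM
compound 3, `CCc1ccc(C(=O)Nc2cccc(NC(=O)COc3ccc4c(=O)ccoc4c3)c2)cc1`: 235 nM

In an assay on isolated protein for inhibition of Rho-associated protein kinase 1 (Homo sapiens), read by scintillation counting, radiometric assay and 33P incorporation, with a stated time of 40 min, in the presence of a further agent that is not named here (on this read-out higher numbers stand for weaker inhibition and lower numbers for stronger inhibition), compound 1 returns only a limit, > 10000 nM, not a number. Compound 2 likewise returns only a limit in this assay, > 10000 nM. For the measured compounds named here, compound 3 is therefore the one member of the set with a measured half-maximal inhibitory concentration, 235 nM, against the limit of > 10000 nM in this assay, at which 2 of the 3 values shown sit, for the other two, so there is no measured step to lean on.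

The next compound, compound 4 `Cc1cc(C(=O)Nc2cccc(NC(=O)COc3ccc4c(=O)ccoc4c3)c2)ccc1C(F)(F)F`, differs from compound 3 in a single place: a group of 11 heavy atoms (8 carbon, 3 fluorine; one six-membered aromatic ring of carbon only) in place of a group of 8 heavy atoms (8 carbon; one six-membered aromatic ring of carbon only), on a carbonyl carbon. The rest of the shared core is unchanged, as is the carbonyl carbon and its amide-type nitrogen neighbour.

With no measured step of this kind shown, the expectation for compound 4 is a change of roughly the size of the scatter, in no confident direction, expressed as the step of a 1.3-fold higher number from compound 3 to compound 4 (0.11 log units; within the scatter). Compound 4 is thus estimated at 300 nM in this assay, with a range from 80 nM to 1500 nM.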

Compound 4, half-maximal inhibitory concentration: 460 nM
Beside the measured number, compound 4's estimate is 1.5-fold (0.19 log units) below it, within the range that was stated.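

The earlier compounds shown here offered no measured step at this place; in this assay, replacing 4-ethylphenyl with the fluorine-bearing aromatic group of 11 heavy atoms gives a 2.0-fold higher number from compound 3 to compound 4 (0.29 log units; within the scatter). The carbonyl carbon bearing the amide-type nitrogen therefore accepts this larger group with the shared core unchanged, and compound 4 still returns a measured number rather than a limit. Nothing shown gives a reason for the size of this step.

On these data alone, only these two aromatic groups can be read at this place, so it remains open whether an amine, a carboxylic acid or a longer alkyl chain there would retain inhibition. Compounds 1 and 2 each differ from compound 3 in more than one place, so their limits cannot be assigned to any single change.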